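Swapping the indazole for an indole on the aminopurine nitrogen

This account rests on a few compounds, and the source may have more. Where it says the series, first, only, none or still open, it means among the compounds named here.

Measured compounds:
- compound 1, `COC(=O)[C@H]1C=C[C@@H](Nc2ncnc3c2nnn3[C@@H]2C[C@@H](COS(N)(=O)=O)[C@@H](O)C2)C1`, 80.9 nM
- compound 2, `NS(=O)(=O)OC[C@@H]1C[C@@H](n2nnc3c(Nc4n[nH]c5ccccc45)ncnc32)C[C@@H]1O`, only a limit, > 10000 nM

The two measured compounds share a core and differ only in the group on the nitrogen on the aromatic ring. In an assay on a protein complex for inhibition of NEDD8 activating enzyme (Homo sapiens), read by HTRF, with a stated time of 2 h, in the presence of a further agent that is not named here (on this read-out higher numbers stand for weaker inhibition and lower numbers for stronger inhibition), compound 1 gives 80.9 nM. In this assay compound 2 reaches only the limit of the measurement, > 10000 nM, so no number is known for it; this is the limit of > 10000 nM in this assay, at which 1 of the 2 values shown sits. The step of an at least 120-fold higher number from compound 1 to compound 2 (2.09 log units; beyond the scatter) is therefore a lower bound on the loss.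

Compound 3, `NS(=O)(=O)OC[C@@H]1C[C@@H](n2nnc3c(Nn4ccc5ccccc54)ncnc32)C[C@@H]1O`, keeps everything of compound 2 except that (1H-indol-1-yl in place of 1H-indazol-3-yl on a nitrogen on an aromatic ring). Going by the values given here, the only measured step that touches this position is the one from compound 1 to compound 2, which was large and ended at the limit; it says nothing about how one bicyclic aromatic group compares with another, and no measured pair shows an indole against an indazole. Since compound 2 already sits at the limit, a small step in either direction would remain unseen, and the expected step that the limit leaves unreadable from compound 2 to compound 3 is accordingly none that can be resolved beyond the scatter. Compound 3 is therefore estimated at 15000 nM, within a range from 3000 nM to 60000 nM, most likely again reported only as a limit.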

Compound 3, half-maximal inhibitory concentration: > 10000 nM
Compound 3: only a limit was reported (the forecaster's own chance of this, stated with the estimate: 70%); the middle value does not contradict the limit.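

In this assay the indole-bearing compound gives the same kind of result as the indazole-bearing one, with an at least 120-fold higher number from compound 1 to compound 3 (2.09 log units; beyond the scatter). A second bicyclic aromatic group on this nitrogen therefore also loses the measurable inhibition that the group of compound 1 gives, so the loss is not confined to the 1H-indazol-3-yl group. The 1H-indol-1-yl group has no hydrogen-bond donor where the 1H-indazol-3-yl group has one, yet this change brings back no measurable inhibition, and the step between the two compounds cannot be read: the limit of > 10000 nM in this assay, at which 2 of the 3 values shown sit.

Compound 1 remains the only compound with a number at this position, so the compounds shown do not separate the part played by its non-aromatic ring from that of the other atoms in its group. Nor do they show how a plain cyclopentyl group, or a carboxylic acid on that ring, would read in this assay, or whether any bicyclic aromatic group on this nitrogen could give a value short of the limit.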